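Swapping a Biphenyl Thiourea for a Methoxyphenyl Thiourea

The source may hold more compounds than are shown below. What is called first, only, known or untested is meant among the compounds shown, and "the series" means these compounds.

Three compounds share one core. In a functional assay on HL-60 cells (Homo sapiens) for antiproliferative activity, with a stated time of 24 h (on this read-out lower numbers stand for stronger inhibition and higher numbers for weaker inhibition), compound 1 `NC(=O)c1c(NC(=O)c2ccccc2Cl)sc2c1CCN(Cc1ccccc1Cl)C2` gives 2900 nM; compound 2 `NC(=O)c1c(NC(=O)c2ccccc2Cl)sc2c1CCN(C(=S)Nc1ccccc1C(F)(F)F)C2` gives 10600 nM; compound 3 `NC(=O)c1c(NC(=O)c2ccccc2Cl)sc2c1CCN(C(=S)Nc1ccccc1-c1ccccc1)C2` gives 34400 nM, the highest of the three numbers, with the step of a 3.2-fold higher number from compound 2 to compound 3 (0.51 log units; beyond the scatter) and its gap to compound 1 both beyond the scatter. Compound 4 `COc1ccc(NC(=S)N2CCc3c(sc(NC(=O)c4ccccc4Cl)c3C(N)=O)C2)cc1` differs from compound 3 by 4-methoxyphenyl in place of 2-phenylphenyl on an amide-type nitrogen. For the measured compounds named here, the only measured step touching this aryl group on the thiourea is a 3.2-fold higher number from compound 2 to compound 3 (0.51 log units; beyond the scatter), where the number rose with the 2-phenylphenyl group; no measured step covers a methoxy substituent. Given a 3.2-fold higher number from compound 2 to compound 3 (0.51 log units; beyond the scatter), the number for compound 4 is expected to fall back toward that of compound 2, a 2.9-fold lower number from compound 3 to compound 4 (0.46 log units; beyond the scatter). The estimate for compound 4 in this assay is 12000 nM, ranging from 4000 nM to 40000 nM.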

Compound 4, half-maximal inhibitory concentration: 15700 nM
For compound 4 the middle estimate is 1.3-fold (0.12 log units) below the measured one, within the range that was stated.
By their numbers in this assay, from the lowest: compound 1; then compounds 2 and 4 (each within the scatter of the next); then compound 3.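

In this assay, the size of the number depends on which aryl group sits on the thiourea nitrogen: 4-methoxyphenyl in place of 2-phenylphenyl gives a 2.2-fold lower number from compound 3 to compound 4 (0.34 log units; beyond the scatter) and so reverses part of the rise seen with 2-phenylphenyl. Against 2-(trifluoromethyl)phenyl, the 4-methoxyphenyl group shows no real separation (a 1.5-fold higher number from compound 2 to compound 4 (0.17 log units; within the scatter)). Compound 4 still stands apart from compound 1 (a 5.4-fold higher number from compound 1 to compound 4 (0.73 log units; beyond the scatter)), so this thiourea does not match the number of the group on the ring nitrogen of compound 1.

On these data alone, whether an amine or a carboxylic acid on this aryl ring would move the number remains open. Nothing shown here gives a reason for these shifts.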